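The source may hold more compounds than are shown below. What is called first, only, known or untested is meant among the compounds shown, and "the series" means these compounds.

Measured compounds in a functional assay on the whole organism (Abdomen, strain Swiss) for inhibition, with Mus musculus as the target, with stated times of 30 min, 10 min and 5 min, at a dose of 40 mg/kg by the oral route; on this read-out lower numbers stand for a weaker effect and higher numbers for a stronger effect at the one dose given:

- compound 1, `CCCC(=O)c1c(C)nn(CCCN2CCN(c3ccc(C)cc3)CC2)c(=O)c1N`, 32%
- compound 2, `Cc1c(C#N)c(-c2ccccc2)nn1CCCN1CCN(c2ccc(F)cc2)CC1`, 51%

Compound 2 holds the highest of the two numbers, and its gap to compound 1 lies beyond the scatter. For the measured compounds named here, no step between two measured compounds that differ in one place is known, so the series gives no guide to a change at this ring.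

Compound 3, `Cc1c(C#N)c(-c2ccccc2)nn1CCCN1CCN(c2ccc([N+](=O)[O-])cc2)CC1`, differs from compound 2 as follows: nitro in place of fluoro on an aromatic carbon. In this assay a step of about a number 6 percentage points lower from compound 2 to compound 3 (within the scatter) is expected, small and not clearly beyond the scatter. Compound 3 is estimated at 45%, within 25% to 65%.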

Compound 3, a percentage reported as inhibition, in the whole organism at one dose (the size of the read-out at that dose, not a potency): 49%
The estimate for compound 3 lay 4 percentage points below the measured number; the measured number falls inside the stated range.
By their numbers in this assay, from the lowest: compound 1; then compounds 3 and 2 (each within the scatter of the next).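

In this assay, the change from 4-fluorophenyl to 4-nitrophenyl gives a number 2 percentage points lower from compound 2 to compound 3 (within the scatter). For the compounds shown here, this is the first one-place step, and at this position on the aromatic ring the two groups cannot be told apart at the one dose given. Nothing available bears on the reason for this result.

Going by these compounds, whether an amine or a carboxylic acid in the same place would also stay within the scatter remains open. So does whether this holds on a core other than the one shared by compound 2 and compound 3.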